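The source may hold more compounds than are shown below. What is called first, only, known or untested is meant among the compounds shown, and "the series" means these compounds.

Measured compounds:
- Compound 1 `CC(C)C(Cc1ncc[nH]1)c1ccc(-c2ccc3cccc(F)c3c2)[nH]c1=O`: 76 nM
- Compound 2 `CC(C)C(c1ccc(-c2ccc3cccc(F)c3c2)[nH]c1=O)N1CCCCC1=O`: 40 nM
- Compound 3 `CC(C)C(Nc1nccs1)c1ccc(-c2ccc3cccc(F)c3c2)[nH]c1=O`: 10 nM

In a functional assay on CHO cells for antagonist activity at prostaglandin E2 receptor EP3 subtype (Homo sapiens), read by cAMP accumulation (a lower number here means a stronger inhibitor, a higher number a weaker inhibitor), compound 3 gives the lowest of the three numbers; the nearest is compound 2 at a 4.0-fold lower number from compound 2 to compound 3 (0.60 log units; beyond the scatter) and the furthest compound 1 at a 7.6-fold lower number from compound 1 to compound 3 (0.88 log units; beyond the scatter).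

Compound 4 `CC(C)C(Cc1nnn[nH]1)c1ccc(-c2ccc3cccc(F)c3c2)[nH]c1=O` has (1H-tetrazol-5-yl)methyl in place of (1,3-thiazol-2-yl)amino on a saturated chain carbon bound to an aromatic carbon and a saturated chain carbon. Within the data shown here, no measured step covers a tetrazole, but compound 1 carries a methyl-linked azole in the same place, and the step to the thiazolylamino of compound 3 was a 7.6-fold lower number from compound 1 to compound 3 (0.88 log units; beyond the scatter). Reversing that kind of change is therefore expected to raise the number in this assay, roughly back toward compound 1, by about a 5.0-fold higher number from compound 3 to compound 4 (0.70 log units; beyond the scatter). For compound 4 the estimate in this assay is 50 nM, with a range from 15 nM to 200 nM.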

Compound 4, half-maximal inhibitory concentration: 134 nM
Compound 4: the middle estimate sits 2.7-fold (0.43 log units) below what was measured, and the stated range covers the measured number.
By their numbers in this assay, from the lowest: compound 3; then compounds 2, 1 and 4 (each within the scatter of the next, the first and the last beyond it).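

Replacing the (1,3-thiazol-2-yl)amino with (1H-tetrazol-5-yl)methyl is a large loss in this assay (a 13-fold higher number from compound 3 to compound 4 (1.13 log units; beyond the scatter)), and the tetrazole also falls behind the 2-oxopiperidin-1-yl group (a 3.4-fold higher number from compound 2 to compound 4 (0.53 log units; beyond the scatter)). Swapping 1H-imidazol-2-yl for 1H-tetrazol-5-yl on the same methyl link separates nothing (a 1.8-fold higher number from compound 1 to compound 4 (0.25 log units; within the scatter)), so this change of ring does not tell these two azoles apart. Nothing measured here explains these differences.

The compounds shown leave open whether the low number of compound 3 comes from its amino link or its thiazole ring. A (1,3-thiazol-2-yl)methyl group or a phenylamino group at this position would separate the two.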